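Bulkier side chain on the aminoacyl anilide of the core

The source may hold more compounds than are shown below. What is called first, only, known or untested is meant among the compounds shown, and "the series" means these compounds.

Compound 3 `CC(C)[C@H](N)C(=O)Nc1cc2cc[nH]c(=O)c2cc1Cl` gives the lowest number of the three measured in an assay on isolated protein for inhibition of Rho-associated protein kinase 2 (Homo sapiens) (a lower number here means a stronger inhibitor, a higher number a weaker inhibitor), 12 nM. Compound 2 `CC(C)[C@@H](N)C(=O)Nc1cc2cc[nH]c(=O)c2cc1Cl` gives 240 nM and compound 1 `N[C@@H](C(=O)Nc1cc2cc[nH]c(=O)c2cc1Cl)C1CCCCC1` gives 400 nM; the step of a 20-fold lower number from compound 2 to compound 3 (1.30 log units; beyond the scatter) is large, and the step of a 1.7-fold lower number from compound 1 to compound 2 (0.22 log units; within the scatter) is within the scatter. The large step rests on (the fact that compounds 2 and 3 differ only in the configuration as drawn), the two compounds sharing every atom and bond.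

Compound 4 `CC(C)(C)C[C@@H](N)C(=O)Nc1cc2cc[nH]c(=O)c2cc1Cl` is not yet measured. Its change from compound 3 is 1-amino-3,3-dimethylbutyl in place of 1-amino-2-methylpropyl on a carbonyl carbon. Going by the values given here, the only measured change of this side chain, a 1.7-fold lower number from compound 1 to compound 2 (0.22 log units; within the scatter), moved the number within the scatter, so exchange of the carbon part alone gives no ground to expect a step beyond the scatter. The measured step that dominates the series, a 20-fold lower number from compound 2 to compound 3 (1.30 log units; beyond the scatter), concerns the configuration at the chain carbon, and the counted difference between compound 3 and compound 4 does not state that the drawn stereocentres agree, so the estimate must carry a range wide enough to cover either outcome.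

For compound 4 the expected value in this assay is 150 nM, with a range of 20 nM to 1200 nM. This estimate corresponds to a step of a 13-fold higher number from compound 3 to compound 4 (1.10 log units; beyond the scatter), expected to be weaker than compound 3 but with wide uncertainty.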

Compound 4, half-maximal inhibitory concentration: 110 nM
The estimate for compound 4 lay 1.4-fold (0.13 log units) above the measured number; the range from low to high includes it.
By their numbers in this assay, from the lowest: compound 3; then compound 4; then compounds 2 and 1 (each within the scatter of the next).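

In this assay, going by these compounds alone, neopentyl gives the first change of the carbon part alone that lies beyond the scatter, at the configuration drawn for compound 4 (a 2.2-fold lower number from compound 2 to compound 4 (0.34 log units; beyond the scatter); a 3.6-fold lower number from compound 1 to compound 4 (0.56 log units; beyond the scatter)), whereas isopropyl in place of cyclohexyl had stayed within it. The carbon part on this chain carbon therefore does move the number at that configuration, though only modestly, and the open-chain neopentyl gives a lower number than either isopropyl or cyclohexyl. Compound 3 keeps its lead (a 9.2-fold higher number from compound 3 to compound 4 (0.96 log units; beyond the scatter)), but that step changes the side chain and the drawn configuration together, and the only clean measure of configuration remains the pair of compound 2 and compound 3: (the fact that compounds 2 and 3 differ only in the configuration as drawn).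

As far as these compounds go, whether neopentyl in the configuration of compound 3 would gain over isopropyl as it does in the other configuration remains open, so the two contributions to that step cannot yet be separated. Equally open, from the compounds shown here alone, are a phenyl ring or a carboxylic acid in place of neopentyl, and a hydroxyl in place of the amine.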